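A few compounds are considered here, and "the series" means these few. Any claim that something is new, unique, unknown or untested is made for them only; others in the source may bear on it.

Working notes on the series. Among the compounds with values here, in a functional assay on cells (T-cell, Homo sapiens) for inhibition (on this read-out lower numbers stand for stronger inhibition and higher numbers for weaker inhibition), compound 1 `COc1ccc(-c2cnc3nc(N)nc(N4CCN(c5ccc(C)cc5)CC4)c3n2)cc1OC` gives 300 nM and compound 2 `COc1ccc(-c2cnc3nc(N)nc(N4CCN(C(=O)NCc5ccc(F)cc5)CC4)c3n2)cc1OC` gives 37 nM, the lowest of the two numbers, the sole measured step being an 8.1-fold lower number from compound 1 to compound 2 (0.91 log units; beyond the scatter). Compound 3 `COc1ccc(-c2cnc3nc(N)nc(N4CCN(C(=O)Nc5ccccc5)CC4)c3n2)cc1OC` differs from compound 2 only by phenyl in place of 4-fluorobenzyl on an amide-type nitrogen. Within the data shown here, no measured step alters the group on the amide-type nitrogen while keeping the urea, so the earlier step does not bear directly on this change, and no movement beyond the scatter is expected in this assay. Compound 3 is therefore estimated at 50 nM, range 15 nM to 160 nM, an expected step of a 1.4-fold higher number from compound 2 to compound 3 (0.13 log units; within the scatter).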

Compound 3, half-maximal inhibitory concentration: 3.4 nM
Estimate against measurement, compound 3: 15-fold (1.17 log units) above; measured number outside the range, below it.
By their numbers in this assay, from the lowest: compound 3; then compound 2; then compound 1.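

The group on the amide-type nitrogen is a sensitive position in this urea series: phenyl in place of 4-fluorobenzyl gives an 11-fold lower number from compound 2 to compound 3 (1.04 log units; beyond the scatter). On the ring amine nitrogen, phenylcarbamoyl in place of 4-methylphenyl gives an 88-fold lower number from compound 1 to compound 3 (1.95 log units; beyond the scatter), which places the phenyl urea lowest of the three compounds. Nothing available accounts for the result.

The change removes the fluorine and shortens benzyl to phenyl together, so the compounds shown do not separate the two; 4-fluorophenyl or plain benzyl would. As far as these compounds go, how a pyridyl or cyclohexyl group reads on this nitrogen also stays open.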